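A few compounds are considered here, and "the series" means these few. Any claim that something is new, unique, unknown or untested is made for them only; others in the source may bear on it.

Three measured compounds share one core and differ only in the group hanging from the carbonyl carbon or in the thiocarbonyl of the ring. Compound 1 `CCOC(=O)C1=C(C)NC(=O)NC1c1cn(-c2ccccc2)nc1-c1ccccc1` carries an ethyl ester; in a functional assay on MCF7 cells (Homo sapiens) for inhibition, read by sulforhodamine B assay, with a stated time of 24 h (on this read-out higher numbers stand for weaker inhibition of growth and lower numbers for stronger inhibition of growth), compound 1 gives 60800 nM. Compound 2 `CC1=C(C(=O)Nc2ccccc2)C(c2cn(-c3ccccc3)nc2-c2ccccc2)NC(=O)N1` carries an anilide in its place, and in this assay compound 2 gives 80600 nM; the step of a 1.3-fold higher number from compound 1 to compound 2 (0.12 log units; within the scatter) shows that this swap changed little. Compound 3 `CC1=C(C(=O)Nc2ccccc2)C(c2cn(-c3ccccc3)nc2-c2ccccc2)NC(=S)N1` has the same anilide with a thiocarbonyl in the ring, and in this assay compound 3 gives 88200 nM. Its number sits close to those of compound 2 and compound 1, and both gaps lie within the usual scatter, so the three compounds cannot be separated on these data.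

Compound 4 `CC1=C(C(=O)Nc2ccccc2Cl)C(c2cn(-c3ccccc3)nc2-c2ccccc2)NC(=S)N1` differs from compound 3 in one place: chloro in place of hydrogen on an aromatic carbon. For the measured compounds named here, no measured step touches this position; the only step in hand is the ester-to-anilide swap from compound 1 to compound 2, which stayed within the scatter. With nothing pointing either way, the expected step of a 1.0-fold lower number from compound 3 to compound 4 (0.02 log units; within the scatter) is no change beyond the scatter. The value expected for compound 4 in this assay is therefore 85000 nM, with a range from 40000 nM to 180000 nM.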

Compound 4, concentration for 50% growth inhibition: 68800 nM
The estimate for compound 4 lay 1.2-fold (0.09 log units) above the measured number, within the range that was stated.
By their numbers in this assay, from the lowest: compounds 1, 4, 2 and 3 (each within the scatter of the next).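

Replacing phenyl with 2-chlorophenyl on the anilide gives a 1.3-fold lower number from compound 3 to compound 4 (0.11 log units; within the scatter) in this assay, so compound 4 cannot be told apart from compound 3 on these data. For the compounds shown here, the earlier compounds varied only the ester or anilide and the thiocarbonyl of the ring, so this is the first reading from the aromatic ring of the anilide, and it shows that a chloro group ortho to a large group leaves the two compounds inseparable in this read-out. No separate measurement bears on this result, so nothing here can say how the chlorine acts, if it acts at all.

One chlorine at one position cannot show how this ring responds in general, and a methoxy group, a nitro group, a carboxylic acid or an amine in the same place could give a quite different reading. As far as these compounds go, it also remains open whether chloro on another carbon of this ring, or on the anilide of compound 2 with its carbonyl in the ring, would give a number separable from those of the parent compounds.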